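This account rests on a few compounds, and the source may have more. Where it says the series, first, only, none or still open, it means among the compounds named here.

Measured so far:
compound 1 `O=C1NC(=O)/C(=C\c2ccc(OCC(=O)N3N=C(c4ccccc4)CC3c3ccccc3)cc2)S1`, 1600 nM
compound 2 `O=C1NC(=O)/C(=C\c2ccc(OCC(=O)N3N=C(c4ccccc4)CC3c3ccc(C(F)(F)F)cc3)cc2)S1`, 1000 nM

In an assay on cells for inhibition of histone deacetylase 4 (Homo sapiens), read by fluorescence, with a stated time of 30 min (a lower number here means a stronger inhibitor, a higher number a weaker inhibitor), compound 1 and compound 2 are indistinguishable within the scatter: a 1.6-fold lower number from compound 1 to compound 2 (0.20 log units; within the scatter). Compound 3 `O=C1NC(=O)/C(=C\c2ccc(OCC(=O)N3N=C(c4ccc(F)cc4)CC3c3ccccc3)cc2)S1` differs from compound 1 by fluoro in place of hydrogen on an aromatic carbon, a single small atom on the phenyl ring. Going by the values given here, the only measured step that bears on such a substitution, a 1.6-fold lower number from compound 1 to compound 2 (0.20 log units; within the scatter), was within the scatter, so no step beyond the scatter is expected for compound 3 either: a 1.1-fold lower number from compound 1 to compound 3 (0.06 log units; within the scatter). Compound 3 is therefore expected to give 1400 nM, somewhere between 700 nM and 2800 nM.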

Compound 3, half-maximal inhibitory concentration: 4200 nM
For compound 3 the middle estimate is 3.0-fold (0.48 log units) below the measured one; measured number above the stated range.
By their numbers in this assay, from the lowest: compounds 2 and 1 (each within the scatter of the next); then compound 3.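

In this assay, going by these compounds alone, the change from phenyl to 4-fluorophenyl gives a 2.6-fold higher number from compound 1 to compound 3 (0.42 log units; beyond the scatter), the only step beyond the scatter here, so a single fluoro at this place yields a weaker inhibitor. The trifluoromethyl step, a 1.6-fold lower number from compound 1 to compound 2 (0.20 log units; within the scatter), sits elsewhere in the molecule and says little about this place. No measurement on hand explains the loss.

Still open, on these data alone, is whether a larger group here, such as chloro or methoxy, or an amine, would move the number further, or whether the effect is specific to fluoro.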